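The compounds below may be only part of what the source reports. "The series", "measured", "known", "first", "only" and "open" are said of these compounds alone.

Compound 1 `O=C1/C(=C/c2ccccc2Cl)CCCc2ccccc21`: in a functional assay on Molt4/C8 cells (Homo sapiens) for inhibition (a higher number here means a weaker inhibitor, a lower number a stronger inhibitor), compound 1 gives 37100 nM.
Compound 2 `O=C(/C=C/c1cccc([N+](=O)[O-])c1)c1ccccc1`: compound 2 gives 8530 nM.
Compound 3 `O=C1/C(=C/c2ccc(Cl)cc2Cl)CCCc2ccccc21`: compound 3 reaches only > 500000 nM, which is a limit of the assay and not a number.

Compound 1 stands highest of the two numbers; the number of compound 2 is lower. Going by the values given here, the one measured step, an at least 13-fold higher number from compound 1 to compound 3 (1.12 log units; beyond the scatter), adds chloro and sends the value to the limit (the limit of > 500000 nM in this assay, at which 1 of the 3 values shown sits).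

Compound 4 `O=C1/C(=C/c2ccccc2F)CCCc2ccccc21` differs from compound 1 by fluoro in place of chloro on an aromatic carbon. Among the compounds with values here, no measured step exchanges one halogen for another, so that step gives no direct guide. Compound 4 is therefore expected to stay close to compound 1, with a step of a 1.1-fold higher number from compound 1 to compound 4 (0.03 log units; within the scatter), inside the scatter. The estimate for compound 4 is 40000 nM, ranging from 15000 nM to 120000 nM.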

Compound 4, half-maximal inhibitory concentration in the Molt4/C8 assay: 42100 nM
Estimate against measurement, compound 4: 1.1-fold (0.02 log units) below, and the stated range covers the measured number.
By their numbers in the Molt4/C8 assay, from the lowest: compound 2; then compounds 1 and 4 (each within the scatter of the next). At a limit, above all of these: compound 3.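

In the Molt4/C8 assay the exchange of halogen on this aromatic carbon gives a 1.1-fold higher number from compound 1 to compound 4 (0.05 log units; within the scatter), so at this position fluoro serves in place of chloro with no readable change in inhibition. In a physicochemical assay for lipophilicity (a lower number here means a more polar compound, a higher number a more lipophilic compound), compound 1 gives 5.04 and compound 4 gives 4.55, so the same exchange separates the two compounds in partition coefficient while their inhibition numbers stay within the scatter of each other.

Open, from the compounds shown here alone, is whether a non-halogen group at this place, such as methoxy or an amine, would hold the inhibition number of compound 1 or shift it.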